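Shortening a Chain on a Non-Cytotoxic Core

A few compounds are considered here, and "the series" means these few. Any claim that something is new, unique, unknown or untested is made for them only; others in the source may bear on it.

Measured so far:
- compound 1, `Cc1[nH]c2ccccc2c(=O)c1Cc1ccccc1`: in an ADME assay on J774 cells (Mus musculus) for cytotoxicity (a higher number here means that more compound is needed for the effect, a lower number that less compound is needed), compound 1 gives > 40100 nM, a limit of the assay.
- compound 2, `CCCCCCCc1c(C)[nH]c2cc(OC)c(Cl)cc2c1=O`: in this assay compound 2 gives > 37100 nM, also a limit.

Compound 2 therefore stands only at the limit of > 37100 nM in this assay, at which 1 of the 2 values shown sits. Compound 1 stands at the limit of > 40100 nM in this assay, at which 1 of the 2 values shown sits. Compound 3, `COc1cc2[nH]c(C)c(C)c(=O)c2cc1Cl`, differs from compound 2 by hydrogen in place of hexyl on a saturated chain carbon bound to an aromatic carbon. Among the measured compounds shown here, no step between measured compounds is available, and both sit at limits, so in this assay no step beyond the usual scatter is expected from compound 2 to compound 3. Compound 3 is expected near 40000 nM (range 20000 nM to 100000 nM), most likely again reported as a limit. That expectation corresponds to a step that the limit leaves unreadable from compound 2 to compound 3.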

Compound 3, half-maximal effective concentration: 12200 nM
Compound 3: middle estimate off by 3.3-fold (0.52 log units), on the high side; measured number outside the range, below it.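

Shortening heptyl to methyl at this position gives an at least 3.0-fold lower number from compound 2 to compound 3 (0.48 log units; beyond the scatter) in this assay, so less compound is needed for the cytotoxic effect. Among the compounds shown here, compound 3 is the first compound here with a number rather than a limit, which shows that this position can change the read-out, something compound 1 and compound 2 could not show. From the compounds shown here alone, the true size of the step stays unknown, since compound 2 sits at a limit: the limit of > 37100 nM in this assay, at which 1 of the 3 values shown sits.

Going by these compounds, whether a butyl chain at this position would give a number or a limit stays open. On these data alone, it is also open whether the number falls gradually as the chain shortens or only with the methyl of compound 3.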